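A few compounds are considered here, and "the series" means these few. Any claim that something is new, unique, unknown or untested is made for them only; others in the source may bear on it.

Of the compounds shown here, three have so far been measured in a physicochemical assay for lipophilicity, read by spectrophotometry, using the shake flask method, measured as octanol-water partition; a higher number here means a more lipophilic compound, a lower number a more polar compound. Compound 1 `FC(F)OCCc1ccccc1` gives 3.16. Compound 2 `FC(F)SCCc1ccccc1` gives 3.16, and the step of no change at the digits printed from compound 1 to compound 2 (within the scatter) shows that swapping the oxygen-linked group for a sulfur-linked one left the reading where it was. Compound 3 `[O-][S+](CCc1ccccc1)C(F)F` gives 1.42, the lowest of the three numbers, standing well beyond the scatter under both compound 1 and compound 2.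

The next compound, compound 4 `C[S+]([O-])CCc1ccccc1`, differs from compound 3 by methyl in place of difluoromethyl on a sulfur. Going by the values given here, none of the measured steps touches this kind of change: the single measured step concerns the atom linking the chain to the difluoromethyl group, not the group on the sulfur itself, so it offers no direct guide to the size of the step in this assay. What the numbers do show is that the oxidised sulfur of compound 3 sits far below its neighbours.

Compound 4 is expected to stay near compound 3, with a small downward move of a number 0.37 log units lower from compound 3 to compound 4 (beyond the scatter) estimated. Compound 4 is therefore expected to read about 1.05, within a range from 0.55 to 1.55.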

Compound 4, partition coefficient: 0.63
Estimate against measurement, compound 4: 0.42 log units above, within the range that was stated.
By their numbers in this assay, from the lowest: compound 4; then compound 3; then compounds 1 and 2 (each within the scatter of the next).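

Methyl in place of difluoromethyl on a sulfur gives, in this assay, a number 0.79 log units lower from compound 3 to compound 4 (beyond the scatter), which shows for the first time that the group at this place can shift the reading while the sulfur's oxygen and the saturated chain carbon stay unchanged. Larger differences appear when the whole chain-end group is exchanged, with a number 2.53 log units lower from compound 2 to compound 4 (beyond the scatter) and a number 2.53 log units lower from compound 1 to compound 4 (beyond the scatter), so compound 4 now has the lowest number of the set, beyond the scatter of every other compound. Nothing shown here gives a measured explanation for these differences.

The compounds shown leave open how trifluoromethyl or ethyl on the same sulfur would read. They also leave open whether methylsulfanyl or methoxy in place of the matching difluoromethyl groups would bring a step of similar size.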